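From Methylamino to Hydroxy on a Carbonyl Carbon

A few compounds are considered here, and "the series" means these few. Any claim that something is new, unique, unknown or untested is made for them only; others in the source may bear on it.

Compound 1 `O=C(O)COc1ccncc1-c1ccc2ccccc2c1`, compound 2 `O=C(O)/C=C/c1ccncc1-c1ccc2ccccc2c1` and compound 3 `CNC(=O)CCc1ccncc1-c1ccc2ccccc2c1` share one core. In a functional assay on HCT-116 cells (Homo sapiens) for inhibition, read by MTT assay, with a stated time of 72 h (on this read-out higher numbers stand for weaker inhibition of growth and lower numbers for stronger inhibition of growth), compound 1 is recorded as "not determined" (no result reported). Compound 2 gives > 30000 nM, which is a limit of the assay and not a number. Among the compounds with values here, compound 3 gives 19300 nM, the only actual number among the three.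

Compound 4 `O=C(O)CCc1ccncc1-c1ccc2ccccc2c1` awaits measurement. It differs from compound 3 by hydroxy in place of methylamino on a carbonyl carbon, with hydroxy in place of methylamino on a carbonyl carbon, so 2-carboxyethyl replaces 2-(methylcarbamoyl)ethyl.

Within the data shown here, only one measured step bears on this change: an at least 1.5-fold lower number from compound 2 to compound 3 (0.19 log units; that floor lies within the scatter). Compound 2 also carries a carboxy group and sits at the limit of > 30000 nM in this assay, at which 1 of the 3 values shown sits, so the direction of the expectation rests on that single limit. A small move toward weaker inhibition in this assay is therefore expected, with nothing beyond the scatter. The estimated step is a 1.5-fold higher number from compound 3 to compound 4 (0.16 log units; within the scatter). For compound 4 the estimate is 28000 nM, with an expected range from 12000 nM to 60000 nM.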

Compound 4, concentration for 50% growth inhibition: > 30000 nM
Compound 4: a limit, no number (the forecaster's own chance of this, stated with the estimate: 45%); at least 1.0-fold (0.02 log units) between middle value and limit.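

In this assay, hydroxy in place of methylamino on a carbonyl carbon gives an at least 1.5-fold higher number from compound 3 to compound 4 (0.19 log units; that floor lies within the scatter), so this floor alone does not establish a real loss of growth inhibition. With the 2-carboxyethyl group, as with the 2-carboxyethenyl group, the carboxylic acid yields no actual number, and the step from compound 2 to compound 4 cannot be read, as both entries are limits. Compound 2 and compound 4 now sit together at the top of the measurable range, while compound 1, also a carboxylic acid, has no result to add: the limit of > 30000 nM in this assay, at which 2 of the 4 values shown sit.

Still open, as far as these compounds go, is how far compound 2 and compound 4 truly lie from compound 3. Also open, from the compounds shown here alone, is whether an ethylamino or dimethylamino group on a carbonyl carbon would give a different result from the methylamino group of compound 3, which gives 19300 nM.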